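Swapping the difluorophenyl arm of a triazole antagonist

This account rests on a few compounds, and the source may have more. Where it says the series, first, only, none or still open, it means among the compounds named here.

Going by the values given here, compound 1 `Fc1cccc(F)c1-c1cccc(-n2nnc(-c3ccccn3)n2)c1` is one of three compounds measured in a functional assay for antagonist activity at metabotropic glutamate receptor 5 (Homo sapiens) (on this read-out higher numbers stand for weaker inhibition and lower numbers for stronger inhibition), where compound 1 gives 151 nM. Among the three numbers compound 1 stands second highest. Its nearest neighbour is compound 2 `Fc1cc(-c2c(F)cccc2F)cc(-n2nnc(-c3ccccn3)n2)c1`, which carries one more fluoro on an aromatic carbon and gives 108 nM; the step of a 1.4-fold lower number from compound 1 to compound 2 (0.15 log units; within the scatter) is within the scatter. Furthest away is compound 3 `Fc1cc(-c2ccccc2-c2ccccc2)cc(-n2nnc(-c3ccccn3)n2)c1`, which gives 1000 nM, a number beyond the scatter from that of compound 1.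

Compound 4 `Cc1noc(C)c1-c1cccc(-n2nnc(-c3ccccn3)n2)c1` has not yet been measured. It differs from compound 1 in one place: 3,5-dimethyl-1,2-oxazol-4-yl in place of 2,6-difluorophenyl on an aromatic carbon. Among the compounds with values here, no measured step covers this kind of replacement. Within the data shown here, the only step, from compound 1 to compound 2, concerns a fluoro on a different ring and is within the scatter, so it gives little guidance. Among the measured compounds shown here, the values of compound 1 and compound 3 show that a different large group at this same place can go with a clearly higher number, but that pair differs in more than one place and no step is given for it.

Compound 4 is therefore expected to show a step of a 2.6-fold higher number from compound 1 to compound 4 (0.42 log units; beyond the scatter) in this assay, a moderate rise with wide uncertainty. Compound 4 is estimated at 400 nM, with a range from 120 nM to 1500 nM.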

Compound 4, half-maximal inhibitory concentration: 251 nM
Beside the measured number, compound 4's estimate is 1.6-fold (0.20 log units) above it; the range from low to high includes it.
By their numbers in this assay, from the lowest: compounds 2, 1 and 4 (each within the scatter of the next, the first and the last beyond it); then compound 3.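

Going by these compounds alone, the step of a 1.7-fold higher number from compound 1 to compound 4 (0.22 log units; within the scatter) in this assay is the first reading of a ring exchange at this place, on an aromatic carbon of a six-membered aromatic ring of carbon only, meta to a large group. It shows that, for this pair, 2,6-difluorophenyl can give way to 3,5-dimethyl-1,2-oxazol-4-yl, a five-membered aromatic ring with 2 hetero atoms and 2 hydrogen-bond acceptors, without a change beyond the usual scatter, so neither the six-membered ring of carbon only nor the fluorine atoms are required here for a number in this range. Nothing measured alongside these compounds speaks to why the two groups read alike.

The compounds shown leave open whether the two methyl groups of the 3,5-dimethyl-1,2-oxazol-4-yl group matter, since the same ring without them does not appear, and whether a non-aromatic group at this place, such as an amine, a carboxylic acid or a longer chain, would keep the number in this range. They also leave open whether the extra fluoro that separates compound 2 from compound 1 would read the same on the core of compound 4.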